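The compounds below may be only part of what the source reports. "The series", "measured", "known", "first", "only" and "open" are said of these compounds alone.

This account follows compound 1, `CCCSc1nc(N/N=C/c2cccnc2)c2nnn(Cc3ccccc3)c2n1`, in a functional assay on ECa-109 cells (Homo sapiens) for antiproliferative activity, read by MTT assay, with a stated time of 72 h; on this read-out higher numbers stand for weaker inhibition and lower numbers for stronger inhibition. Compound 1 gives > 64000 nM, which is a limit of the assay rather than a measured number. Compound 2, `CCCSc1nc(N/N=C(\C)c2ccccc2O)c2nnn(Cc3ccccc3Cl)c2n1`, also gives > 64000 nM, again a limit. Among the measured compounds shown here, compound 3, `CCCSc1nc(N/N=C(\C)c2ccccc2O)c2nnn(Cc3ccc(O)cc3)c2n1`, reaches 15900 nM, the only number among the three. For the measured compounds named here, the single step between compounds that differ in one place is an at least 4.0-fold lower number from compound 2 to compound 3 (0.60 log units; beyond the scatter), and its size is bounded by the limit of > 64000 nM in this assay, at which 2 of the 3 values shown sit, so only its lower bound is known. Compound 4, `CCCSc1nc(N/N=C/c2ccccc2F)c2nnn(Cc3ccccc3)c2n1`, has not yet been measured. It differs from compound 1 by 2-fluorophenyl in place of pyridin-3-yl on a carbon with a double bond to nitrogen. Going by the values given here, this change sits on the carbon with a double bond to nitrogen, whereas the one measured step alters the group on the saturated chain carbon bound to an aromatic nitrogen; no measured step therefore bears directly on the change from compound 1 to compound 4. Compound 1 stands at the limit, so the expected step is a step that the limit leaves unreadable from compound 1 to compound 4, meaning no clear movement beyond the scatter. For compound 4 the estimate in this assay is 70000 nM, with a range from 20000 nM to 200000 nM, and the assay is expected most likely to report only a limit again.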

Compound 4, half-maximal inhibitory concentration: > 64000 nM
Compound 4: a limit, no number; the forecaster's own chance of this, stated with the estimate: 70%; the middle value lies beyond the limit too.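

In this assay compound 4 gives > 64000 nM, a limit and not a number. Compound 1 is also at a limit, so no step can be read between compound 1 and compound 4: the limit of > 64000 nM in this assay, at which 3 of the 4 values shown sit. The compounds shown leave open whether 2-fluorophenyl in place of pyridin-3-yl on the carbon with a double bond to nitrogen changes the inhibition at all.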